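The compounds below may be only part of what the source reports. "The series", "measured", "known", "first", "only" and "open" are said of these compounds alone.

Of the compounds shown here, three that share one core have been tested in an assay on isolated protein for inhibition of serine protease 1 (Bos taurus); a lower number here means a stronger inhibitor, a higher number a weaker inhibitor. Compound 1 `Cc1c(F)c(Oc2cccc(N)c2)nc(Oc2cccc(C(=N)N)c2)c1F` carries an amino group on one outer aromatic ring. For compound 1 the assay reports only a limit, > 5000 nM. Compound 2 `Cc1c(F)c(Oc2cccc(NS(C)(=O)=O)c2)nc(Oc2cccc(C(=N)N)c2)c1F` gives 1900 nM, and compound 3 `Cc1c(F)c(Oc2cccc(OC(C)C)c2)nc(Oc2cccc(C(=N)N)c2)c1F` gives 2900 nM. Compound 2 and compound 3 are separated by a 1.5-fold higher number from compound 2 to compound 3 (0.18 log units; within the scatter), so they stand together, and the remaining value is the limit of compound 1.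

Compound 4 `Cc1c(F)c(Oc2cccc(CCC(=O)N(C)C)c2)nc(Oc2cccc(C(=N)N)c2)c1F` has not yet been measured. It differs from compound 2 in one place: 2-(dimethylcarbamoyl)ethyl in place of methanesulfonamido on an aromatic carbon.

Two measured steps speak to such a swap. The step of an at least 2.6-fold lower number from compound 1 to compound 2 (0.42 log units; beyond the scatter) shows that building out the group on this carbon lowered the number, and a 1.5-fold higher number from compound 2 to compound 3 (0.18 log units; within the scatter) shows that exchanging methanesulfonamido for a different uncharged group left the number essentially where it was. Given a 1.5-fold higher number from compound 2 to compound 3 (0.18 log units; within the scatter), the expected step is a 1.3-fold higher number from compound 2 to compound 4 (0.12 log units; within the scatter), with no shift beyond the scatter. Compound 4 is estimated at 2500 nM, within a range from 1000 nM to 7000 nM.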

Compound 4, inhibition constant: 4900 nM
Compound 4: middle estimate off by 2.0-fold (0.29 log units), on the low side; the measured number falls inside the stated range.
By their numbers in this assay, from the lowest: compounds 2, 3 and 4 (each within the scatter of the next, the first and the last beyond it). At a limit, above all of these: compound 1.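

Replacing methanesulfonamido with 2-(dimethylcarbamoyl)ethyl gives a 2.6-fold higher number from compound 2 to compound 4 (0.41 log units; beyond the scatter), so in this assay this position does respond to the choice of uncharged group, which the step from compound 2 to compound 3 did not show. Set against isopropoxy, the same chain gives a 1.7-fold higher number from compound 3 to compound 4 (0.23 log units; within the scatter), so this pair cannot be told apart. Only the two ends of the series, compound 2 and compound 4, are separated. The step of an at least 1.0-fold lower number from compound 1 to compound 4 (0.00 log units; that floor lies within the scatter) cannot be read. Compound 1 is known only as a limit: the limit of > 5000 nM in this assay, at which 1 of the 4 values shown sits.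

The swap changes the chain and removes the hydrogen on the sulfonamide nitrogen together, so the compounds shown cannot say which of these matters. A methanesulfonamido group with a methyl on that nitrogen, or a carboxylic acid on a similar chain, would help to separate the two.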